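Swapping pyridin-2-yl for pyridin-3-yl across two cores

The source may report more compounds than this note shows. Statements on the series, on what has been measured and on what is new or still open speak of the compounds shown alone.

Measured so far:
compound 1, `O=S(=O)(/C=C/c1ccccn1)c1ccccc1F`, gives 1050 nM in an assay on U2OS cells for activation of nuclear factor erythroid 2-related factor 2 (Homo sapiens), read by beta-arrestin recruitment, with a stated time of 6 h; a lower number here means that less compound is needed, a higher number that more compound is needed for the effect.
compound 2, `O=S(=O)(/C=C/c1ccccn1)c1cccc(Cl)c1`, gives 1430 nM in this assay.
compound 3, `O=S(=O)(/C=C/c1cccnc1)c1ccccc1F`, gives 6860 nM in this assay.

Compound 1 and compound 2 differ in their cores; how the two cores differ is not broken down here, and their values lie within the usual scatter of each other. Compound 3 differs from compound 1 in one place: pyridin-3-yl in place of pyridin-2-yl on a double-bonded chain carbon bound to a double-bonded chain carbon That single change gave a 6.5-fold higher number from compound 1 to compound 3 (0.82 log units; beyond the scatter). The unmeasured compound 4, `O=S(=O)(/C=C/c1cccnc1)c1cccc(Cl)c1`, stands to compound 2 exactly as compound 3 stands to compound 1: pyridin-3-yl in place of pyridin-2-yl on a double-bonded chain carbon bound to a double-bonded chain carbon The change is the same and sits at the same place. For the measured compounds named here, the step from compound 2 to compound 4 is expected to be of similar size, a 5.6-fold higher number from compound 2 to compound 4 (0.75 log units; beyond the scatter), an expectation resting on the single earlier example, a 6.5-fold higher number from compound 1 to compound 3 (0.82 log units; beyond the scatter). Going by the values given here, with only one example to lean on, the step on the core of compound 2 could turn out smaller or larger. Compound 4 is therefore estimated at 8000 nM in this assay, most likely between 3500 nM and 20000 nM.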

Compound 4, half-maximal effective concentration: 3520 nM
Compound 4: middle estimate off by 2.3-fold (0.36 log units), on the high side; low and high end bracket the measured number.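

Replacing pyridin-2-yl with pyridin-3-yl on the second core raised the number again in this assay, a 2.5-fold higher number from compound 2 to compound 4 (0.39 log units; beyond the scatter), so the change pointed the same way on both cores. Set side by side, the two steps do not differ by more than repeated measurements would be expected to: the same change on two cores in this assay, a 6.5-fold higher number (0.82 log units; beyond the scatter) from compound 1 to compound 3 and a 2.5-fold higher number (0.39 log units; beyond the scatter) from compound 2 to compound 4, 2.7-fold (0.42 log units) apart, within the scatter of two such steps

In these compounds, then, the change carried over from one core to the other in direction and, within the scatter, in size, but two cores are too few to show that it would do so on any further core, and these numbers do not reveal what lies behind the step.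

From the compounds shown here alone, how pyridin-4-yl or a plain phenyl ring would behave in the same place remains open. Going by these compounds, it is also open whether the step would hold on a core carrying a methoxy group or a nitrile instead of the fluorine or chlorine seen here.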